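The source may report more compounds than this note shows. Statements on the series, on what has been measured and on what is new or still open speak of the compounds shown alone.

Working notes on the series. The shared core carries a benzylamine-type substituent and a chalcogen group; compound 1 `CSc1ccc(CNc2nc([SeH])nc3ccccc23)cc1`, compound 2 `C[Se]c1nc(NCc2ccccc2)c2ccccc2n1` and compound 3 `CSc1nc(NCc2ccccc2)c2ccccc2n1` have been run in a functional assay on CCRF-CEM cells (Homo sapiens) for cytotoxicity, read by MTT assay, with a stated time of 72 h; a higher number here means a weaker inhibitor of growth, a lower number a stronger inhibitor of growth. Compound 1 gives 71900 nM, compound 2 gives 39800 nM and compound 3 gives 87900 nM in this assay. Compound 2 has the lowest of the three numbers; compound 1 lies within the scatter of it, while compound 3 is beyond it, the single-point step being a 2.2-fold higher number from compound 2 to compound 3 (0.34 log units; beyond the scatter).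

Compound 4 `CSc1ccc(CNc2nc([Se]C)nc3ccccc23)cc1` is the next member, differing from compound 2 by methylsulfanyl in place of hydrogen on an aromatic carbon. Among the compounds with values here, no measured pair differs in this one place alone: the only single-point step, from compound 2 to compound 3, concerns the chalcogen group on the core, not the benzyl ring. Compound 1 carries the methylsulfanyl group on its benzyl ring, but also a different chalcogen group, so its number against compound 2 only shows two values within the scatter. With nothing pointing either way, no step beyond the scatter is expected for compound 4 in this assay, an expected step of a 1.0-fold higher number from compound 2 to compound 4 (0.00 log units; within the scatter). Compound 4 is therefore estimated at 40000 nM, between 15000 nM and 110000 nM.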

Compound 4, concentration for 50% growth inhibition: 48700 nM
Beside the measured number, compound 4's estimate is 1.2-fold (0.09 log units) below it, and the stated range covers the measured number.
By their numbers in this assay, from the lowest: compounds 2, 4, 1 and 3 (each within the scatter of the next, the first and the last beyond it).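

In this assay, methylsulfanyl in place of hydrogen, on an aromatic carbon para to a large group, now has a reading in one place alone: a 1.2-fold higher number from compound 2 to compound 4 (0.09 log units; within the scatter), so the series tolerates this change at this position without a step beyond the scatter. Methyl in place of hydrogen on the selenium can also be read for the first time, with methylsulfanyl present in both compounds: a 1.5-fold lower number from compound 1 to compound 4 (0.17 log units; within the scatter), again no step beyond the scatter. No evidence is at hand that bears on either step.

From the compounds shown here alone, whether an amine or a carboxylic acid at this position would give a step beyond the scatter remains open. So does the effect of a longer chain in place of methyl on the selenium, and whether the step from selenium to sulfur recurs with methylsulfanyl present.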